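A few compounds are considered here, and "the series" means these few. Any claim that something is new, unique, unknown or untested is made for them only; others in the source may bear on it.

Series notes. Compound 1 `Clc1[nH]ccc2ncnc1-2`, compound 2 `Sc1[nH]ccc2ncnc1-2` and compound 3 `OC[C@H]1OC(n2cnc3c(S)nccc32)[C@H](O)[C@@H]1O` have been measured in a functional assay (Homo sapiens) for inhibition of Nucleic Acid, tested at 100 uM; a lower number here means less inhibition, a higher number more inhibition at the concentration tested (going by the name of the read-out). Compound 1 gives 6% in this assay, compound 2 gives 26%, and compound 3 gives 6%. Compound 2 stands highest of the three: compound 1, its nearest neighbour, lies beyond the scatter below it, and so does compound 3, which lies furthest. For the measured compounds named here, the one step between measured compounds that differ in a single place is a number 20 percentage points higher from compound 1 to compound 2 (beyond the scatter), that is, sulfanyl in place of chloro on an aromatic carbon; it shows that exchanging the group on that aromatic carbon moves the read-out by a modest amount.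

Compound 4 `CN(C)c1[nH]ccc2ncnc1-2` is not yet measured. It differs from compound 2 by dimethylamino in place of sulfanyl on an aromatic carbon. Going by the values given here, only the step from compound 1 to compound 2 bears on this change, since it concerns the group on the same aromatic carbon; no measured pair shows dimethylamino anywhere. Among the compounds with values here, compound 2 sits at the top of the measured numbers and the one relevant step was modest, so a modest step downward, or none beyond the scatter, is expected in this assay. Compound 4 is therefore estimated at 12%, with a range from 0% to 30%. This means an expected step of a number 14 percentage points lower from compound 2 to compound 4 (beyond the scatter).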

Compound 4, a percentage reported as inhibition, at one concentration (the size of the read-out at that concentration, not a potency): 8%
Compound 4: middle estimate off by 4 percentage points, on the high side; the measured number falls inside the stated range.
By their numbers in this assay, from the lowest: compounds 1, 3 and 4 (each within the scatter of the next); then compound 2.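

In this assay, a second replacement of sulfanyl on this aromatic carbon, next to the ring nitrogen, gives a number 18 percentage points lower from compound 2 to compound 4 (beyond the scatter) and so shows that the higher number of compound 2 does not depend on the comparison with chloro alone. Dimethylamino and chloro cannot be told apart at this position, with a number 2 percentage points higher from compound 1 to compound 4 (within the scatter) in the same assay, although the two groups share neither their atoms nor their size in heavy atoms. Among these three compounds, which differ only at this position, sulfanyl alone stands apart from the other two groups, and no measured evidence bears on why this is so.

On these data alone, whether a primary amine or a methylsulfanyl group on the same aromatic carbon would keep the number of compound 2 or match compound 1 and compound 4 remains open, and such groups would show whether the free sulfanyl is needed or a smaller nitrogen group can serve in its place. As far as these compounds go, the read-out also comes from one concentration only, so how the potency of compound 2 compares with that of compound 4 remains open as well.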